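Removing the Heptyl Group from Compound 2

The source may report more compounds than this note shows. Statements on the series, on what has been measured and on what is new or still open speak of the compounds shown alone.

In a functional assay on SW480 cells (Homo sapiens) for antiproliferative activity, read by MTT assay, with a stated time of 48 h (on this read-out lower numbers stand for stronger inhibition and higher numbers for weaker inhibition), compound 1 (`CCC(CCO)n1cnc2c(Cl)nc(F)nc21`) gives 19800 nM and compound 2 (`CCCCCCCC(CCO)n1cnc2c(Cl)nc(F)nc21`) gives 26100 nM. Going by the values given here, these two values lie within the scatter of each other, so neither compound can be placed ahead of the other, and compound 2 stands level with the only other measured compound.

Compound 3 (`OCCCn1cnc2c(Cl)nc(F)nc21`) has hydrogen in place of heptyl on a saturated chain carbon bound to an aromatic nitrogen and a saturated chain carbon.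

Among the compounds with values here, only one measured step bears on this change, namely a 1.3-fold higher number from compound 1 to compound 2 (0.12 log units; within the scatter). That step altered the same side chain and stayed within the scatter. It offers no ground for expecting a shift in either direction in this assay, although the data do not show what happens when the whole group is gone. The estimate therefore means a 1.0-fold lower number from compound 2 to compound 3 (0.02 log units; within the scatter), an expected step no larger than the scatter.

For compound 3 the expected value is 25000 nM, with an estimated range from 11000 nM to 60000 nM.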

Compound 3, half-maximal inhibitory concentration: 29700 nM
Estimate against measurement, compound 3: 1.2-fold (0.07 log units) below; the range from low to high includes it.
By their numbers in this assay, from the lowest: compounds 1, 2 and 3 (each within the scatter of the next).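

In this assay, removing the heptyl group altogether gives a 1.1-fold higher number from compound 2 to compound 3 (0.06 log units; within the scatter) and so extends the comparison at this saturated chain carbon from two alkyl groups to no alkyl group at all. Taking away the ethyl group gives a 1.5-fold higher number from compound 1 to compound 3 (0.18 log units; within the scatter) as well, so hydrogen, ethyl and heptyl at this place all give numbers within the scatter of one another, and none of the three compounds can be placed ahead of the others. Nothing measured here accounts for this level result, and no further data bear on it.

The compounds shown leave open whether a different kind of group on this carbon, such as a phenyl ring, an amine or a carboxylic acid, would also give a number level with these three, or whether any such group would move it beyond the scatter. They also leave open what the hydroxyl at the end of the chain contributes, since it stays the same in compound 1, compound 2 and compound 3, and whether replacing it with an amine would change the number.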